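A Fluoro for Methoxy Swap on Compound 3

The source may report more compounds than this note shows. Statements on the series, on what has been measured and on what is new or still open speak of the compounds shown alone.

Compound 1 `COc1ccc(-n2c(SCC(=O)c3ccc(F)cc3)nnc2-c2cc(OC)c(OC)c(OC)c2)cc1`: 58300 nM
Compound 2 `COc1cc(-c2nnc(SCc3ccc(C)cc3)n2-c2ccc(N(C)C)cc2)cc(OC)c1OC`: 37300 nM
Compound 3 `COc1ccc(C(=O)CSc2nnc(-c3cc(OC)c(OC)c(OC)c3)n2-c2ccc(N(C)C)cc2)cc1`: 22000 nM

In a functional assay on PC-3 cells (Homo sapiens) for inhibition, read by MTT assay, with a stated time of 48 h (on this read-out lower numbers stand for stronger inhibition and higher numbers for weaker inhibition), compound 3 gives 22000 nM. This value lies within the scatter of compound 2 and beyond the scatter below compound 1. Compound 4 `COc1cc(-c2nnc(SCC(=O)c3ccc(F)cc3)n2-c2ccc(N(C)C)cc2)cc(OC)c1OC` is the next to be measured, and it departs from compound 3 by fluoro in place of methoxy on an aromatic carbon. Among the compounds with values here, the one measured step is a 1.7-fold lower number from compound 2 to compound 3 (0.23 log units; within the scatter), which stayed within the scatter even though it replaced a whole group. Within the data shown here, compound 1 also carries (4-fluorophenyl)carbonyl, but it differs from compound 3 in more than one place, so it gives no clean step. The data hold no direct measure of this exchange. In this assay no shift beyond the scatter is therefore expected, with only a slight lean towards higher numbers. The expected step is a 1.2-fold higher number from compound 3 to compound 4 (0.09 log units; within the scatter). Compound 4 is estimated at 27000 nM, with an expected range from 12000 nM to 60000 nM.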

Compound 4, half-maximal inhibitory concentration: 42300 nM
Compound 4: middle estimate off by 1.6-fold (0.19 log units), on the low side; the measured number falls inside the stated range.
By their numbers in this assay, from the lowest: compounds 3, 2, 4 and 1 (each within the scatter of the next, the first and the last beyond it).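

In this assay, within the data shown here, the exchange of 4-methoxyphenyl for 4-fluorophenyl gives a 1.9-fold higher number from compound 3 to compound 4 (0.28 log units; within the scatter) and so supplies the first direct reading at this place on the ring, showing that this swap does not carry the number beyond the scatter. Compound 4 also links the other two compounds in single changes: (4-fluorophenyl)carbonyl in place of 4-methylphenyl gives a 1.1-fold higher number from compound 2 to compound 4 (0.05 log units; within the scatter) while dimethylamino in place of methoxy gives a 1.4-fold lower number from compound 1 to compound 4 (0.14 log units; within the scatter) and neither step leaves the scatter. Nothing in the data shown accounts for any of these steps.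

As far as these compounds go, whether a chloro, a hydroxy or an amine in this same place would give a step beyond the scatter remains open. So does whether the fluoro for methoxy exchange reads the same when methoxy rather than dimethylamino sits on the other aromatic ring.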